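Piperazine dithiocarbamate triazoles: swapping the urea amine

The source may hold more compounds than are shown below. What is called first, only, known or untested is meant among the compounds shown, and "the series" means these compounds.

Measured so far:
- compound 1 `CC(C)NC(=O)N1CCN(C(=S)SCc2cn(Cc3ccc(F)cc3)nn2)CC1`: 1660 nM
- compound 2 `CCN(C)C(=O)N1CCN(C(=S)SCc2cn(Cc3ccc(F)cc3)nn2)CC1`: 2150 nM
- compound 3 `Cc1ccc(Cn2cc(CSC(=S)N3CCN(C(=O)NC(C)C)CC3)nn2)cc1`: 4630 nM

All three were tested in a functional assay on MCF7 cells (Homo sapiens) for cytotoxicity, read by MTT assay, with a stated time of 72 h; a lower number here means a stronger inhibitor, a higher number a weaker inhibitor. Compound 1 and compound 2 share one core and differ by ethyl(methyl)amino in place of isopropylamino on a carbonyl carbon, a change that gave a 1.3-fold higher number from compound 1 to compound 2 (0.11 log units; within the scatter). Compound 3 carries a different core, differing from compound 1 by methyl in place of fluoro on an aromatic carbon, and this gave a 2.8-fold higher number from compound 1 to compound 3 (0.45 log units; beyond the scatter), so compound 3 has the highest number of the three.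

Compound 4 `CCN(C)C(=O)N1CCN(C(=S)SCc2cn(Cc3ccc(C)cc3)nn2)CC1` is not yet measured. It differs from compound 3 by ethyl(methyl)amino in place of isopropylamino on a carbonyl carbon, the same change as between compound 1 and compound 2, here on the core of compound 3. Because a 1.3-fold higher number from compound 1 to compound 2 (0.11 log units; within the scatter) was small, a similarly small step is expected, a 1.2-fold higher number from compound 3 to compound 4 (0.07 log units; within the scatter), giving an estimated 5500 nM for compound 4, within 3000 nM to 11000 nM.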

Compound 4, half-maximal inhibitory concentration: 40100 nM
Compound 4: the middle estimate sits 7.3-fold (0.86 log units) below what was measured; the measured number lies above the stated range.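

In this assay, ethyl(methyl)amino in place of isopropylamino gave an 8.7-fold higher number from compound 3 to compound 4 (0.94 log units; beyond the scatter), so the small step seen on the core of compound 1 did not carry over to the core of compound 3: the same change on two cores in this assay, a 1.3-fold higher number (0.11 log units; within the scatter) from compound 1 to compound 2 and an 8.7-fold higher number (0.94 log units; beyond the scatter) from compound 3 to compound 4, 6.7-fold (0.83 log units) apart, beyond the scatter of two such steps. Seen from the other side, methyl in place of fluoro gave a 19-fold higher number from compound 2 to compound 4 (1.27 log units; beyond the scatter), so the size of that step also depends on which amine sits on the carbonyl carbon: the same change on two cores in this assay, a 2.8-fold higher number (0.45 log units; beyond the scatter) from compound 1 to compound 3 and a 19-fold higher number (1.27 log units; beyond the scatter) from compound 2 to compound 4, 6.7-fold (0.83 log units) apart, beyond the scatter of two such steps. These four compounds show that the two changes do not simply add up, but they do not show why.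

Going by these compounds, it remains open whether diethylamino on the carbonyl carbon would behave like ethyl(methyl)amino. On these data alone, it is also open whether chloro on the aromatic carbon would follow fluoro or methyl.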